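Changing the nitrogen substituent of compound 3

The source may report more compounds than this note shows. Statements on the series, on what has been measured and on what is new or still open speak of the compounds shown alone.

Of the compounds shown here, three sharing one core have been tested in a functional assay on MCF7 cells (Homo sapiens) for inhibition, with a stated time of 96 h; a lower number here means a stronger inhibitor, a higher number a weaker inhibitor. Compound 1 `COc1cc(C(=O)c2cn(-c3ccc(F)cc3)cc2-c2nccs2)cc(OC)c1OC` gives 22 nM, compound 2 `COc1cc(C(=O)c2cn(-c3cccc(C)c3)cc2-c2cccnc2)cc(OC)c1OC` gives 52 nM, and compound 3 `COc1cc(C(=O)c2cn(-c3cccc(C)c3)cc2-c2ccncc2)cc(OC)c1OC` gives 65 nM. Compound 3 sits level with compound 2, within the scatter, while compound 1 has a clearly lower number than compound 3.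

Compound 4 `COc1cc(C(=O)c2cn(-c3ccc(F)cc3)cc2-c2ccncc2)cc(OC)c1OC` has not yet been measured. It keeps the pyridin-4-yl group of compound 3 and changes one place: 4-fluorophenyl in place of 3-methylphenyl on an aromatic nitrogen.

For the measured compounds named here, the only measured single change is a 1.3-fold higher number from compound 2 to compound 3 (0.10 log units; within the scatter), which concerns pyridin-4-yl in place of pyridin-3-yl and not the group on nitrogen. Going by the values given here, no measured step isolates the new group. Among the compounds with values here, the one hint is compound 1, which carries 4-fluorophenyl and gives 22 nM, but it also differs from compound 3 in a second place, so only part of that gap can be credited to this change. A small move towards a lower number is therefore expected, and the estimated change is a 1.5-fold lower number from compound 3 to compound 4 (0.19 log units; within the scatter). For compound 4 the estimate is 42 nM, with an expected range from 15 nM to 110 nM.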

Compound 4, half-maximal inhibitory concentration: 9 nM
The estimate for compound 4 lay 4.7-fold (0.67 log units) above the measured number; measured number outside the range, below it.
By their numbers in this assay, from the lowest: compound 4; then compound 1; then compounds 2 and 3 (each within the scatter of the next).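

In this assay the group on the aromatic nitrogen proves to be a sensitive place: 4-fluorophenyl in place of 3-methylphenyl gives a 7.2-fold lower number from compound 3 to compound 4 (0.86 log units; beyond the scatter) even though the two groups match in heavy-atom count and each has one six-membered aromatic ring of carbon only. With 4-fluorophenyl held fixed, pyridin-4-yl in place of 1,3-thiazol-2-yl on the aromatic carbon also gives a step beyond the scatter (a 2.4-fold lower number from compound 1 to compound 4 (0.39 log units; beyond the scatter)), so the group at that carbon counts too, while the earlier exchange of one pyridine for the other stayed within the scatter. Nothing available explains either step.

The exchange on nitrogen removes a methyl group and adds a fluorine at a different ring position all at once, so the compounds shown cannot say which part matters; plain phenyl, 3-fluorophenyl and 4-methylphenyl would separate these parts. Also open, on these data alone, are whether 4-fluorophenyl has the same effect alongside pyridin-3-yl, and how a larger substituent on that ring, such as a dimethylamino group or a carboxylic acid, would fare.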